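The source may hold more compounds than are shown below. What is called first, only, known or untested is meant among the compounds shown, and "the series" means these compounds.

Compound 3 `O[C@@H]1[C@@H](CO/C(S)=N/C2CC2)OC(n2cnc3c(NC4CCOC4)ncnc32)[C@@H]1O` stands highest of the three numbers in an assay on DDT1 cells (Cricetulus griseus) for binding affinity to adenosine receptor A1 (Homo sapiens), read by radioligand binding (on this read-out higher numbers stand for weaker inhibition and lower numbers for stronger inhibition), where compound 3 gives 157 nM; compound 1 `C/N=C(\S)OC[C@H]1OC(n2cnc3c(NC4CCOC4)ncnc32)[C@H](O)[C@@H]1O` gives 45 nM and compound 2 `CC/N=C(\S)OC[C@H]1OC(n2cnc3c(NC4CCOC4)ncnc32)[C@H](O)[C@@H]1O` gives 33 nM. Compound 4 `O[C@@H]1[C@@H](CO/C(S)=N/C2CCCC2)OC(n2cnc3c(NC4CCOC4)ncnc32)[C@@H]1O` differs from compound 3 by cyclopentyl in place of cyclopropyl on a double-bonded nitrogen. Within the data shown here, no measured step exchanges one ring for another, so the nearest guides are a 3.5-fold higher number from compound 1 to compound 3 (0.54 log units; beyond the scatter) and a 4.8-fold higher number from compound 2 to compound 3 (0.68 log units; beyond the scatter), in which cyclopropyl in place of methyl or ethyl went with a modestly higher number, whereas a 1.4-fold lower number from compound 1 to compound 2 (0.13 log units; within the scatter). On these grounds the account expects the move to cyclopentyl to bring a further modest rise or at most no change beyond the scatter, with a 1.8-fold higher number from compound 3 to compound 4 (0.25 log units; within the scatter) as the estimated step. Compound 4 is therefore expected near 280 nM, within 90 nM to 900 nM.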

Compound 4, inhibition constant: 72 nM
Beside the measured number, compound 4's estimate is 3.9-fold (0.59 log units) above it; measured number outside the range, below it.
By their numbers in this assay, from the lowest: compounds 2, 1 and 4 (each within the scatter of the next, the first and the last beyond it); then compound 3.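

In this assay the step of a 2.2-fold lower number from compound 3 to compound 4 (0.34 log units; beyond the scatter) shows that a larger ring on the double-bonded nitrogen does not simply raise the number: cyclopentyl takes back part of the rise seen with cyclopropyl. Set against the chains, the result is a 2.2-fold higher number from compound 2 to compound 4 (0.34 log units; beyond the scatter) starting from ethyl but a 1.6-fold higher number from compound 1 to compound 4 (0.20 log units; within the scatter) starting from methyl. No evidence at hand accounts for the difference between the two rings. Going by these compounds, whether cyclobutyl or cyclohexyl would fall nearer cyclopropyl or cyclopentyl stays open, as does how a propyl chain would compare with ethyl.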